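The compounds below may be only part of what the source reports. "The series", "measured", "known", "first", "only" and "open" are said of these compounds alone.

Among the measured compounds shown here, compound 3 `OCc1ccc2c(c1)CCC(NCCCc1ccccc1)CC2` is one of three compounds measured so far in an assay on cell membranes for displacement of a labelled ligand from Sigma non-opioid intracellular receptor 1 (Cavia porcellus), read by scintillation counting, with stated times of 120 min and 5 min; on this read-out higher numbers stand for weaker inhibition and lower numbers for stronger inhibition. In this assay compound 3 gives 565 nM, the highest of the three numbers. Compound 1 `Oc1ccc2c(c1)CCC(NCCCc1ccccc1)CC2` gives 123 nM, and compound 2 `Oc1ccc2c(c1)CCC(NCCCCc1ccccc1)CC2` gives 211 nM. The step of a 4.6-fold higher number from compound 1 to compound 3 (0.66 log units; beyond the scatter) shows what separates compound 3 from compound 1: a hydroxymethyl group in place of a hydroxy group on the aromatic ring, a change that pushed the number up.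

Compound 4 `OCc1ccc2c(c1)CCC(NCCCCc1ccccc1)CC2` has not yet been measured. It differs from compound 3 in one place: benzyl in place of phenyl on a saturated chain carbon, three bonds along the chain from an amine nitrogen. The same change has already been seen once, between compounds that share the hydroxy group rather than the hydroxymethyl group. That step, a 1.7-fold higher number from compound 1 to compound 2 (0.23 log units; within the scatter), lay within the scatter of repeated measurements, so it gives little reason to expect a large movement here.

On that basis the step from compound 3 to compound 4 is expected to be small, a 1.5-fold higher number from compound 3 to compound 4 (0.18 log units; within the scatter), most likely a slight rise that stays within the scatter. Compound 4 is therefore estimated to give about 850 nM in this assay, with a likely range from 400 nM to 2000 nM.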

Compound 4, inhibition constant: 41 nM
Compound 4: the middle estimate sits 21-fold (1.32 log units) above what was measured; measured number outside the range, below it.
By their numbers in this assay, from the lowest: compound 4; then compounds 1 and 2 (each within the scatter of the next); then compound 3.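

On the hydroxymethyl core, benzyl in place of phenyl on the saturated chain carbon gives a 14-fold lower number from compound 3 to compound 4 (1.14 log units; beyond the scatter), so a change that stayed within the scatter on the hydroxy core has a large effect here, and the two readings disagree: the same change on two cores in this assay, a 1.7-fold higher number (0.23 log units; within the scatter) from compound 1 to compound 2 and a 14-fold lower number (1.14 log units; beyond the scatter) from compound 3 to compound 4, 24-fold (1.37 log units) apart, beyond the scatter of two such steps

The aromatic change also reverses direction when the chain carries benzyl, with hydroxymethyl in place of hydroxy giving a 5.1-fold lower number from compound 2 to compound 4 (0.71 log units; beyond the scatter), although the same swap raised the number when the chain carried phenyl: the same change on two cores in this assay, a 4.6-fold higher number (0.66 log units; beyond the scatter) from compound 1 to compound 3 and a 5.1-fold lower number (0.71 log units; beyond the scatter) from compound 2 to compound 4, 24-fold (1.37 log units) apart, beyond the scatter of two such steps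

Neither change therefore has a single effect of its own in this assay, since what each one does depends on the group present at the other place.

The compounds shown leave open whether phenethyl, or a longer chain, would lower the number further on the hydroxymethyl core, and whether a methoxy group or a carboxylic acid on the aromatic carbon would show the same dependence on the chain. These four compounds show that the two places are linked, but they cannot tell what links them.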